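A few compounds are considered here, and "the series" means these few. Any claim that something is new, unique, unknown or untested is made for them only; others in the source may bear on it.

Compound 1 `COc1ccc(C(=O)/C=C/c2ccc(N(C)C)cc2)c2c1C=CC(C)(C)O2`: 730 nM
Compound 2 `COc1ccc(C(=O)/C=C/c2ccc(C(F)(F)F)cc2)c2c1C=CC(C)(C)O2`: > 10000 nM

Going by the values given here, in a functional assay on HepG2 cells (Homo sapiens) for antiproliferative activity, read by MTT assay, with a stated time of 24 h (a higher number here means a weaker inhibitor, a lower number a stronger inhibitor), compound 1 gives 730 nM, the only exact number available so far. Compound 2 is recorded at > 10000 nM, which is a limit of the assay and not a number. That limit is captured by the limit of > 10000 nM in this assay, at which 1 of the 2 values shown sits.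

The next compound, compound 3 `COc1ccc(C(=O)/C=C/c2ccccn2)c2c1C=CC(C)(C)O2`, keeps the core of compound 1 but carries pyridin-2-yl in place of 4-(dimethylamino)phenyl on a double-bonded chain carbon bound to a double-bonded chain carbon.

Among the compounds with values here, one measured step bears on this change: an at least 13-fold higher number from compound 1 to compound 2 (1.13 log units; beyond the scatter). This large step, beyond the scatter, replaced dimethylamino with trifluoromethyl on an aromatic carbon. Compound 3 also lacks dimethylamino, so a move towards a higher number, meaning weaker inhibition, seems more likely than no change. Within the data shown here, the guide is imperfect, since the group entering compound 3 is a different one and no measured compound carries it. The expected change is a 5.5-fold higher number from compound 1 to compound 3 (0.74 log units; beyond the scatter), probably smaller than the measured step. For compound 3 the estimated value is 4000 nM, with an expected range from 1000 nM to 16000 nM.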

Compound 3, half-maximal inhibitory concentration: 5760 nM
Compound 3: middle estimate off by 1.4-fold (0.16 log units), on the low side, within the range that was stated.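

In this assay, replacing the whole 4-(dimethylamino)phenyl with pyridin-2-yl gives a 7.9-fold higher number from compound 1 to compound 3 (0.90 log units; beyond the scatter). This shows that the number at this place on the double-bonded chain carbon also moves when the aromatic ring itself is exchanged, not only when one group on the ring is swapped. Compound 3 gives a real number, 5760 nM. The absence of dimethylamino therefore does not by itself carry a compound to the limit of the assay, yet compound 1 keeps the lowest number of the three, and both steps away from it lie beyond the scatter.

Compound 2 stands at > 10000 nM, which is a limit of the assay and not a number, so the step between it and compound 3 cannot be read. The compounds shown also leave open whether the higher number of compound 3 follows from losing dimethylamino or from the ring nitrogen of pyridin-2-yl, a question that a plain phenyl, or a phenyl ring carrying morpholine or a primary amine in the place of dimethylamino, would bear on.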